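Urotensin-2 receptor series: removing the piperazine cyclobutyl group

The compounds below may be only part of what the source reports. "The series", "measured", "known", "first", "only" and "open" are said of these compounds alone.

Measured so far:
compound 1 `CCN1CCN(c2cccc3c2CN([C@H](CCCNS(=O)(=O)c2c[nH]cn2)c2ccc(OC)c(OC)c2)C3=O)CC1`, 25 nM
compound 2 `COc1ccc([C@@H](CCCN(C)S(=O)(=O)c2cccs2)N2Cc3c(cccc3N3CCN(C4CCC4)CC3)C2=O)cc1OC`, 44 nM
compound 3 `CCN1CCN(c2cccc3c2CN([C@H](CCCNC(=O)c2cccs2)c2ccc(OC)c(OC)c2)C3=O)CC1`, 18 nM

In an assay on RMS13 cells for displacement of a labelled ligand from Urotensin-2 receptor (Homo sapiens), read by scintillation proximity assay (a lower number here means a stronger inhibitor, a higher number a weaker inhibitor), compound 2 gives the highest of the three numbers; compound 1 lies nearest and within the scatter, while compound 3 lies furthest and beyond it. For the measured compounds named here, the only measured step, a 1.4-fold lower number from compound 1 to compound 3 (0.14 log units; within the scatter), concerns the group on the open-chain amine nitrogen and does not touch the ring amine nitrogen. Compound 4 `COc1ccc([C@@H](CCCN(C)S(=O)(=O)c2cccs2)N2Cc3c(cccc3N3CCNCC3)C2=O)cc1OC` differs from compound 2 by hydrogen in place of cyclobutyl on an amine nitrogen in a ring. Going by the values given here, no measured pair bears on this change, so the direction is open; the expected step is a 1.6-fold higher number from compound 2 to compound 4 (0.20 log units; within the scatter), and a wide range is kept. For compound 4 the expected value in this assay is 70 nM, between 20 nM and 250 nM.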

Compound 4, inhibition constant: 49 nM
Compound 4: middle estimate off by 1.4-fold (0.15 log units), on the high side; the range from low to high includes it.
By their numbers in this assay, from the lowest: compounds 3, 1, 2 and 4 (each within the scatter of the next, the first and the last beyond it).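

For the compounds shown here, this is the first measured step on the amine nitrogen in a ring: in this assay, a 1.1-fold higher number from compound 2 to compound 4 (0.05 log units; within the scatter). The cyclobutyl group can therefore be replaced by hydrogen without a change that rises above the scatter, and 4-cyclobutylpiperazin-1-yl and piperazin-1-yl cannot be told apart in this pair. No evidence is available that accounts for this result.

Open, from the compounds shown here alone, is whether acetyl or benzyl on this nitrogen would also stay within the scatter. Also open, going by these compounds, is whether hydrogen there would give the same result with the thiophene amide side chain of compound 3.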